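The source may hold more compounds than are shown below. What is called first, only, known or untested is meant among the compounds shown, and "the series" means these compounds.

Of the compounds shown here, three sharing one core have been tested in a functional assay on the whole organism with Mus musculus as the target, with a stated time of 0.5 h; a lower number here means that less compound is needed, a higher number that more compound is needed for the effect. Compound 1 `CC[C@]1(c2ccccc2)OC(=O)N(C)C1=O` gives 69 mg/kg, compound 2 `CCC1(c2ccccc2)OC(=O)NC1=O` gives 39 mg/kg, and compound 3 `CCC1(c2ccccc2)OC(=O)N(C)C1=O` gives 45 mg/kg. Compound 2 has the lowest number of the three, but its gaps to the other two lie within the usual scatter of this kind of measurement. Compound 4 `CC[C@]1(c2ccccc2)OC(=O)NC1=O` has not yet been measured. Compared with compound 2, (the two compounds have the same atoms and bonds; at least one stereo element is drawn with a configuration in one of them and without one in the other: 1 of 1 stereo elements differ; a stereocentre at a saturated ring carbon is drawn without a configuration in compound 2 and R in compound 4). One measured step involves the same kind of change, in the opposite direction: a 1.5-fold lower number from compound 1 to compound 3 (0.19 log units; within the scatter). No step beyond the scatter is therefore expected for compound 4 in this assay. Compound 4 is estimated to give 42 mg/kg, in a range from 22 mg/kg to 80 mg/kg, which means an expected step of a 1.1-fold higher number from compound 2 to compound 4 (0.03 log units; within the scatter).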

Compound 4, dose for half-maximal effect: 108 mg/kg
Estimate against measurement, compound 4: 2.6-fold (0.41 log units) below; measured number above the stated range.
By their numbers in this assay, from the lowest: compounds 2, 3, 1 and 4 (each within the scatter of the next, the first and the last beyond it).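

In this assay, drawing the saturated ring carbon as R now goes with a step beyond the scatter, a 2.8-fold higher number from compound 2 to compound 4 (0.44 log units; beyond the scatter), although the same kind of change between compound 1 and compound 3 stayed within it. Hydrogen in place of methyl on the ring nitrogen gives a 1.6-fold higher number from compound 1 to compound 4 (0.19 log units; within the scatter), so this change remains small among the compounds drawn as R. The nitrogen change also agrees between the two cores: the same change on two cores in this assay, a 1.2-fold higher number (0.06 log units; within the scatter) from compound 2 to compound 3 and a 1.6-fold lower number (0.19 log units; within the scatter) from compound 4 to compound 1, 1.8-fold (0.26 log units) apart, within the scatter of two such steps. The compounds shown leave open how the opposite configuration at this carbon behaves, and whether a longer chain or an amine on the shared core would alter these steps.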